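Piperidine for pyridylpiperazine on the phenyl-urea core

The source may hold more compounds than are shown below. What is called first, only, known or untested is meant among the compounds shown, and "the series" means these compounds.

Compound 1 `COc1ccc(NC(=O)Nc2nc(Sc3c[nH]c4ccccc34)cc(N3CCCCC3)n2)cc1` gives 13500 nM in a functional assay on A549 cells (Homo sapiens) for inhibition, with a stated time of 72 h; a lower number here means a stronger inhibitor, a higher number a weaker inhibitor. Compound 2 `COc1ccc(NC(=O)Nc2nc(Sc3c[nH]c4ccccc34)cc(N3CCN(c4ccccn4)CC3)n2)cc1` reaches only the limit > 50000 nM in this assay (the limit of > 50000 nM in this assay, at which 1 of the 3 values shown sits). Compound 3 `O=C(Nc1ccccc1)Nc1nc(Sc2c[nH]c3ccccc23)cc(N2CCN(c3ccccn3)CC2)n1` gives 30300 nM in this assay. The change piperidin-1-yl in place of 4-(pyridin-2-yl)piperazin-1-yl on an aromatic carbon made an at least 3.7-fold lower number from compound 2 to compound 1 (0.56 log units; beyond the scatter). The two cores differ by hydrogen in place of methoxy on an aromatic carbon, which made an at least 1.6-fold lower number from compound 2 to compound 3 (0.21 log units; that floor lies within the scatter). Compound 4 `O=C(Nc1ccccc1)Nc1nc(Sc2c[nH]c3ccccc23)cc(N2CCCCC2)n1` carries the same kind of change, (piperidin-1-yl in place of 4-(pyridin-2-yl)piperazin-1-yl on an aromatic carbon), but here the place is meta to a (phenylcarbamoyl)amino group rather than meta to a ((4-methoxyphenyl)carbamoyl)amino group. In this assay the step is expected to be a 4.3-fold lower number from compound 3 to compound 4 (0.64 log units; beyond the scatter), resting on the step of an at least 3.7-fold lower number from compound 2 to compound 1 (0.56 log units; beyond the scatter). The floor of that step is set by compound 2, whose value > 50000 nM is a limit of the assay. Compound 4 is therefore estimated at 7000 nM, expected between 2500 nM and 20000 nM.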

Compound 4, half-maximal inhibitory concentration: 33100 nM
Beside the measured number, compound 4's estimate is 4.7-fold (0.67 log units) below it; the measured number lies above the stated range.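

Piperidin-1-yl in place of 4-(pyridin-2-yl)piperazin-1-yl does not carry from the core of compound 1 to the core of compound 3 in this assay; there the change gives (a 1.1-fold higher number from compound 3 to compound 4 (0.04 log units; within the scatter)), and the two steps differ: the same change on two cores in this assay, an at least 3.7-fold lower number (0.56 log units; beyond the scatter) from compound 2 to compound 1 and a 1.1-fold higher number (0.04 log units; within the scatter) from compound 3 to compound 4, at least 4.0-fold (0.60 log units) apart, beyond the scatter of two such steps.
Hydrogen in place of methoxy likewise depends on its partner group, giving (a 2.5-fold higher number from compound 1 to compound 4 (0.39 log units; beyond the scatter)) with piperidin-1-yl: the same change on two cores in this assay, an at least 1.6-fold lower number (0.21 log units; that floor lies within the scatter) from compound 2 to compound 3 and a 2.5-fold higher number (0.39 log units; beyond the scatter) from compound 1 to compound 4, at least 4.0-fold (0.60 log units) apart, beyond the scatter of two such steps.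
Compound 2 is a limit of the assay, which leaves the true size of both gaps unfixed, and nothing here gives a reason for them: the limit of > 50000 nM in this assay, at which 1 of the 4 values shown sits.

Still open, going by these compounds, is whether an amine such as morpholin-4-yl or unsubstituted piperazin-1-yl would follow the same dependence on the core. Also open, on these data alone, is whether a chloro group in place of methoxy would behave like methoxy.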